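Widening the Saturated Ring on the Thiocarbonyl Carbon

The source may report more compounds than this note shows. Statements on the series, on what has been measured and on what is new or still open speak of the compounds shown alone.

Compound 2 `Cc1ccnc(/C(N)=N/NC(=S)N2CCCC2)c1` was tested in a functional assay on HeLa cells (Homo sapiens) for cytotoxicity, read by MTT assay, with a stated time of 72 h, tested at 100 uM (on this read-out higher numbers stand for more inhibition of growth at the one concentration tested and lower numbers for less inhibition of growth), and in this assay compound 2 gives 88.1%. Two relatives give a frame for that number. Compound 1 `Cc1ccnc(/C(N)=N/NC(=S)N2CCSCC2)c1` carries thiomorpholin-4-yl on the thiocarbonyl carbon, and in this assay compound 1 gives 91.6%. Compound 3 `N/C(=N\NC(=S)N1CCOCC1)c1ccc(F)cn1` differs from compound 2 in more than one place, and in this assay compound 3 gives 81.2%. On the numbers shown, compound 2 sits between the other two, and its gap to each of them is within the scatter.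

Compound 4 `Cc1ccnc(/C(N)=N/NC(=S)N2CCCCC2)c1` has not yet been measured. It differs from compound 2 at one place: piperidin-1-yl in place of pyrrolidin-1-yl on a thiocarbonyl carbon. For the measured compounds named here, the only measured step that touches this place is a number 3.5 percentage points lower from compound 1 to compound 2 (within the scatter), an exchange of one saturated ring for another on the same thiocarbonyl carbon. That step did not move the read-out beyond the scatter, so another exchange of a saturated ring at this place is expected to leave the read-out essentially unchanged, which is the meaning of the expected step of a number 0.1 percentage points lower from compound 2 to compound 4 (within the scatter). Compound 4 is therefore estimated at 88%, with a range from 76% to 96%.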

Compound 4, percent growth inhibition at one concentration: 70.8%
The estimate for compound 4 lay 17.2 percentage points above the measured number; measured number below the stated range.
By their numbers in this assay, from the lowest: compound 4; then compounds 3, 2 and 1 (each within the scatter of the next, the first and the last beyond it).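

In this assay, the thiocarbonyl carbon turns out not to be a place where one saturated ring can simply stand in for another: piperidin-1-yl in place of pyrrolidin-1-yl gives a number 17.3 percentage points lower from compound 2 to compound 4 (beyond the scatter), and piperidin-1-yl in place of thiomorpholin-4-yl gives a number 20.8 percentage points lower from compound 1 to compound 4 (beyond the scatter). The earlier exchange, a number 3.5 percentage points lower from compound 1 to compound 2 (within the scatter), could not separate pyrrolidin-1-yl from thiomorpholin-4-yl, so the new result shows that the read-out can depend on which ring sits here, with piperidin-1-yl standing apart from the other two, even though neither pyrrolidin-1-yl nor piperidin-1-yl carries a hydrogen-bond donor or acceptor. No measurement at hand gives a reason for this fall.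

Going by these compounds, how the read-out would respond to the larger azepan-1-yl ring, or to an open-chain group such as diethylamino, at this same place remains open. Also open, on these data alone, is whether piperidin-1-yl would lower the number in the same way on other versions of the core, since a single pair of exchanges on one core cannot settle that.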